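The compounds below may be only part of what the source reports. "The series", "measured", "known", "first", "only" and "open" are said of these compounds alone.

Working notes on the series. Among the measured compounds shown here, in a functional assay on HCT-116 cells (Homo sapiens) for inhibition (on this read-out higher numbers stand for weaker inhibition and lower numbers for stronger inhibition), compound 1 (`CCNC(=O)c1noc(-c2cc(C(C)C)c(O)cc2O)c1-c1cc(CO)no1`) gives 13 nM and compound 2 (`CCNC(=O)c1noc(-c2cc(C(C)C)c(O)cc2O)c1-c1cc(CN(C)C)no1`) gives 92 nM as the higher of the two numbers so far. The next change leads to compound 3 (`CCNC(=O)c1noc(-c2cc(C(C)C)c(O)cc2O)c1-c1cc(CN2CCCCC2)no1`), with piperidin-1-yl in place of dimethylamino on a saturated chain carbon bound to an aromatic carbon. For the measured compounds named here, only one measured step bears on this carbon: a 7.1-fold higher number from compound 1 to compound 2 (0.85 log units; beyond the scatter) when dimethylamino replaced hydroxy. Going by the values given here, that step is modest, and it says nothing direct about exchanging dimethylamino for piperidin-1-yl, as no measured pair makes that comparison. A small change is therefore expected, with no firm direction, and the expected step of a 1.1-fold higher number from compound 2 to compound 3 (0.04 log units; within the scatter) stays within the scatter. Compound 3 is estimated at 100 nM in this assay (range 35 nM to 250 nM).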

Compound 3, half-maximal inhibitory concentration: 93 nM
Compound 3: the middle estimate sits 1.1-fold (0.03 log units) above what was measured, within the range that was stated.
By their numbers in this assay, from the lowest: compound 1; then compounds 2 and 3 (each within the scatter of the next).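

In this assay the new comparison sets two groups with a nitrogen against each other on this saturated chain carbon. The step reads as (a 1.0-fold higher number from compound 2 to compound 3 (0.00 log units; within the scatter)), so exchanging dimethylamino for piperidin-1-yl, with its six-membered non-aromatic ring and added heavy atoms, leaves no difference that can be told from scatter. The distance from the hydroxy compound also stays in place (a 7.2-fold higher number from compound 1 to compound 3 (0.85 log units; beyond the scatter)), and compounds 2 and 3 thus sit together on the weaker side of compound 1, a pattern resting on these three compounds alone; no available evidence bears on the reason for this result.

Open, going by these compounds, is whether a morpholin-4-yl or piperazin-1-yl group on this carbon would stay with compounds 2 and 3. Equally open, on these data alone, is whether a methoxy group or a carboxylic acid there would fall closer to compound 1.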